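The source may hold more compounds than are shown below. What is called first, only, known or untested is meant among the compounds shown, and "the series" means these compounds.

Measured in a functional assay on LNCaP cells (Homo sapiens) for antiproliferative activity, read by WST assay, with a stated time of 3 days; on this read-out higher numbers stand for weaker inhibition and lower numbers for stronger inhibition:
- compound 1 `CCCOc1c(-c2cc(OC)c(OC)c(OC)c2)oc2ccccc2c1=O`: 5700 nM
- compound 2 `CCN(CC)CCCOc1c(-c2cc(OC)c(OC)c(OC)c2)oc2ccccc2c1=O`: 37600 nM

Among the compounds with values here, compound 2 at 37600 nM holds the higher number of the two, and its only neighbour is compound 1 at 5700 nM.

The next entry is compound 3 `CCCN(CCC)CCCCOc1c(-c2cc(OC)c(OC)c(OC)c2)oc2ccccc2c1=O`, which differs from compound 2 by (dipropylamino)methyl in place of diethylamino on a saturated chain carbon, three bonds along the chain from an oxygen on an aromatic ring. Cut one bond further out, the change reads 3-(diethylamino)propyl to 4-(dipropylamino)butyl.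

Within the data shown here, only one measured step bears on this: a 6.6-fold higher number from compound 1 to compound 2 (0.82 log units; beyond the scatter), a modest step beyond the scatter. It compares diethylamino with hydrogen on the same chain carbon. Among the measured compounds shown here, no measured pair varies the amine or the chain length, so that step serves only as a rough yardstick for size. A step no larger than that one is expected, and its direction is uncertain. For the measured compounds named here, a lean towards a lower number rests only on compound 1 at 5700 nM being the sole other value. The expected change in this assay is a 2.4-fold lower number from compound 2 to compound 3 (0.37 log units; beyond the scatter). The estimate for compound 3 is 16000 nM, with an expected range of 4000 nM to 50000 nM.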

Compound 3, half-maximal inhibitory concentration: 16800 nM
The estimate for compound 3 lay 1.1-fold (0.02 log units) below the measured number; the measured number falls inside the stated range.
By their numbers in this assay, from the lowest: compound 1; then compound 3; then compound 2.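

In this assay, a 2.2-fold lower number from compound 2 to compound 3 (0.35 log units; beyond the scatter) accompanies the change from 3-(diethylamino)propyl to 4-(dipropylamino)butyl, showing that the number at this position responds to the make-up of the amine-bearing chain. Adding an amine to the propyl chain of compound 1 therefore does not shift the number by one fixed amount: the 4-(dipropylamino)butyl chain gives a 2.9-fold higher number from compound 1 to compound 3 (0.47 log units; beyond the scatter) and the 3-(diethylamino)propyl chain gives a 6.6-fold higher number from compound 1 to compound 2 (0.82 log units; beyond the scatter) in the same direction. Compound 1 still holds the lowest number of the three, so neither amine-bearing chain improves on the plain propyl ether, and the step to compound 3 joins a longer chain with propyl in place of ethyl on the nitrogen, so it cannot be assigned to either change alone.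

The 4-(diethylamino)butyl and 3-(dipropylamino)propyl chains would separate those two changes, while a piperidine ring on the chain or a carboxylic acid at its end would show whether the trend extends beyond open-chain tertiary amines. Nothing available accounts for the shifts in these numbers.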